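Isopropylamino for butyl on the compound 3 chain

A few compounds are considered here, and "the series" means these few. Any claim that something is new, unique, unknown or untested is made for them only; others in the source may bear on it.

Values so far in a functional assay on the whole organism with Mus musculus as the target, in the rotarod test; a higher number here means that more compound is needed for the effect, a lower number that less compound is needed:
- compound 1 `CN(C(=O)CNC(=O)CN1CCCCC1)c1ccc(Cl)cc1C(=O)c1ccccc1Cl` gives > 100 mg/kg as a limit of the assay
- compound 2 `CN(C(=O)CNC(=O)CN)c1ccc([N+](=O)[O-])cc1C(=O)c1ccccc1Cl` gives 10 mg/kg as a number
- compound 3 `CCCCCC(=O)NCC(=O)N(C)c1ccc(Cl)cc1C(=O)c1ccccc1Cl` gives 90 mg/kg as a number

Compound 3 stands highest of the two actual numbers, and compound 2 lies lower, at 10 mg/kg in this pair. Compound 1 sits at a limit and carries no number (the limit of > 100 mg/kg in this assay, at which 1 of the 3 values shown sits).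

The next compound is compound 4 `CC(C)NCC(=O)NCC(=O)N(C)c1ccc(Cl)cc1C(=O)c1ccccc1Cl`, which keeps the shared core of compound 3 and changes one group (isopropylamino in place of butyl on a saturated chain carbon bound to a carbonyl carbon). Isopropylamino takes the place of butyl on a saturated chain carbon bound to a carbonyl carbon.

Among the measured compounds shown here, one measured step bears on this (an at least 1.1-fold lower number from compound 1 to compound 3 (0.04 log units; that floor lies within the scatter)). It puts butyl in place of piperidin-1-yl at that same place, and its floor lies within the scatter. For the measured compounds named here, compound 2 differs from compound 3 in more than one place, so it offers no clean step.

Given an at least 1.1-fold lower number from compound 1 to compound 3 (0.04 log units; that floor lies within the scatter), no step beyond the scatter is expected in this assay for the new group. The expected step is small (a 1.5-fold lower number from compound 3 to compound 4 (0.18 log units; within the scatter)) and leans toward a lower number. For compound 4 the estimate is 60 mg/kg, with an expected range of 20 mg/kg to 130 mg/kg, though a result reported only as a limit remains possible.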

Compound 4, dose for half-maximal effect: 13 mg/kg
The estimate for compound 4 lay 4.6-fold (0.66 log units) above the measured number; measured number outside the range, below it.
By their numbers in this assay, from the lowest: compounds 2 and 4 (each within the scatter of the next); then compound 3. At a limit, above all of these: compound 1.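

In this assay, the place on a saturated chain carbon bound to a carbonyl carbon now gives a step beyond the scatter, a 6.9-fold lower number from compound 3 to compound 4 (0.84 log units; beyond the scatter), whereas the earlier step there had only a floor within the scatter. Isopropylamino replaces butyl with no change in heavy-atom count, and it brings a nitrogen, a hydrogen-bond donor and a hydrogen-bond acceptor that butyl lacks, so the result at this place does not follow from group size as counted in heavy atoms. Isopropylamino in place of piperidin-1-yl also gives a step beyond the scatter, an at least 7.6-fold lower number from compound 1 to compound 4 (0.88 log units; beyond the scatter), but this step is only a floor, with compound 1 reported as a limit: the limit of > 100 mg/kg in this assay, at which 1 of the 4 values shown sits.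

The compounds shown do not separate the nitrogen from the branching, and isobutyl or a plain amino group on the core of compound 4 would be needed to tell these apart. Compound 2 differs from compound 4 in more than one place, so it gives no clean reading of the amine at this position.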